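Fluoro in place of methyl on compound 2

The compounds below may be only part of what the source reports. "The series", "measured", "known", "first", "only" and "open" are said of these compounds alone.

compound 1 `Cc1ccc(CS/C(=C/c2ccc(O)cc2)C(=O)c2ccc(Cl)cc2)cc1`: 10000 nM
compound 2 `Cc1ccc(CS/C(=C/c2c[nH]c3ccc(Br)cc23)C(=O)c2ccc(Cl)cc2)cc1`: 1000 nM
compound 3 `Cc1ccc(CS/C(=C/c2cc([N+](=O)[O-])ccc2F)C(=O)c2ccc(Cl)cc2)cc1`: 1000 nM

These values come from a functional assay on DU-145 cells (Homo sapiens) for inhibition, read by trypan blue exclusion, with a stated time of 96 h; on this read-out higher numbers stand for weaker inhibition of growth and lower numbers for stronger inhibition of growth. Compound 3 and compound 2 stand level at 1000 nM, together the lowest of the three numbers. Compound 1 stands higher at 10000 nM.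

Compound 4 `O=C(/C(=C\c1c[nH]c2ccc(Br)cc12)SCc1ccc(F)cc1)c1ccc(Cl)cc1` carries 4-fluorobenzyl where compound 2 carries 4-methylbenzyl, with fluoro in place of methyl on an aromatic carbon, para to a large group: fluoro in place of methyl on an aromatic carbon.

All measured steps lie elsewhere, in the group on the double-bonded chain carbon: a 10-fold lower number from compound 1 to compound 2 (1.00 log units; beyond the scatter), a 10-fold lower number from compound 1 to compound 3 (1.00 log units; beyond the scatter) and no change at the digits printed from compound 2 to compound 3 (within the scatter). The first two are modest and the third stays within the scatter. None of them measures a change at the 4-methylbenzyl group, so they give no direction for this one.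

With compound 2 at 1000 nM as the anchor, no step beyond the scatter is expected in this assay. The expected step is no change at the digits printed from compound 2 to compound 4 (within the scatter). For compound 4 the estimated value is 1000 nM, with an expected range of 300 nM to 3500 nM.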

Compound 4, concentration for 50% growth inhibition: 50000 nM
Estimate against measurement, compound 4: 50-fold (1.70 log units) below; measured number outside the range, above it.
By their numbers in this assay, from the lowest: compounds 2 and 3 (each within the scatter of the next); then compound 1; then compound 4.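

In this assay, the 4-methylbenzyl group now has a measured change of its own: fluoro in place of methyl, one heavy atom for one, gives a 50-fold higher number from compound 2 to compound 4 (1.70 log units; beyond the scatter). Among these compounds, this step is large, whereas the earlier steps at the group on the double-bonded chain carbon were modest or within the scatter, so this aromatic carbon is a sensitive position. The data at hand offer no explanation for the size of the step.

A chloro, a methoxy or an amine on this aromatic carbon would help show whether the step follows from the loss of methyl or the arrival of fluoro. As far as these compounds go, it also remains open whether the same change would give a step of similar size with the 2-fluoro-5-nitrophenyl group of compound 3.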